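From (Ethylcarbamoyl)amino to Chloromethyl on a Shared Core

The compounds below may be only part of what the source reports. "The series", "measured", "known", "first", "only" and "open" are said of these compounds alone.

Three compounds sharing one core were measured in an assay on isolated protein (strain Sprague-Dawley) for inhibition of Amine oxidase [flavin-containing] A (Rattus norvegicus), read by spectrophotometry, with a stated time of 5 min, tested at 10 uM; on this read-out lower numbers stand for less inhibition and higher numbers for more inhibition at the one concentration tested (going by the name of the read-out). Compound 1 `CC(=O)COc1cc(=O)oc2cc(OCc3cccc(Cl)c3)ccc12` gives 22%. Compound 2 `O=C(O)COc1cc(=O)oc2cc(OCc3cccc(Cl)c3)ccc12` gives 0%, and compound 3 `CCNC(=O)Nc1cc(=O)oc2cc(OCc3cccc(Cl)c3)ccc12` gives 0%. Compound 3 stands level with compound 2 at the digits shown, the two together the lowest of the three numbers; its furthest neighbour is compound 1, since a number 22 percentage points lower from compound 1 to compound 3 (beyond the scatter), while no change at the digits printed from compound 2 to compound 3 (within the scatter). Compound 4 `O=c1cc(CCl)c2ccc(OCc3cccc(Cl)c3)cc2o1` has not yet been measured. It differs from compound 3 in one place: chloromethyl in place of (ethylcarbamoyl)amino on an aromatic carbon. Going by the values given here, the steps that bear on this change are the two that lead into compound 3. The step of a number 22 percentage points lower from compound 1 to compound 3 (beyond the scatter) shows that a 2-oxopropoxy group at this position gave a modest reading, whereas no change at the digits printed from compound 2 to compound 3 (within the scatter) shows that carboxymethoxy and (ethylcarbamoyl)amino both sit at the floor. Among the compounds with values here, no measured step introduces chloromethyl, so the expectation can only rest on the span of the three numbers, from the floor of compound 3 to the modest reading of compound 1. Compound 4 is therefore expected to show a number 10 percentage points higher from compound 3 to compound 4 (within the scatter), a small rise that may well stay within the scatter. The estimate for compound 4 in this assay is 10%, within a range from 0% to 35%.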

Compound 4, a percentage reported as inhibition, at one concentration (the size of the read-out at that concentration, not a potency): 21%
Compound 4: middle estimate off by 11 percentage points, on the low side; low and high end bracket the measured number.
By their numbers in this assay, from the lowest: compounds 2 and 3 (each within the scatter of the next); then compounds 4 and 1 (each within the scatter of the next).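

In this assay, chloromethyl on this aromatic carbon, opposite the ring oxygen, lifts the reading clear of the floor: replacing (ethylcarbamoyl)amino gives a number 21 percentage points higher from compound 3 to compound 4 (beyond the scatter) and replacing carboxymethoxy gives a number 21 percentage points higher from compound 2 to compound 4 (beyond the scatter) in the same assay. Set against 2-oxopropoxy, chloromethyl gives a number 1 percentage points lower from compound 1 to compound 4 (within the scatter) and so cannot be told apart from it, which shows that a reading of this size does not depend on 2-oxopropoxy and that the floor readings of compound 2 and compound 3 are not set by the shared core alone. Nothing at hand explains why these groups part in this way.

Whether the chlorine of chloromethyl matters remains open, since the compounds shown do not include a plain methyl or a hydroxymethyl group on this carbon, nor a primary amine that would separate the urea-type (ethylcarbamoyl)amino group from a simpler nitrogen substituent. All four readings also come from one concentration, so they leave open how the potencies of compound 1 and compound 4 compare.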